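The source may hold more compounds than are shown below. What is called first, only, known or untested is meant among the compounds shown, and "the series" means these compounds.

Series notes, indole sulfonamide set, read in an assay on isolated protein for binding affinity to Alpha-1B adrenergic receptor (Homo sapiens); a lower number here means a stronger inhibitor, a higher number a weaker inhibitor. Compound 1 `CC1CCN(CC[C@H]2CCCN2S(=O)(=O)c2ccc3cc[nH]c3c2)CC1` is measured only as a limit of the assay: in this assay compound 1 gives < 10000 nM. Compound 2 `O=S(=O)(c1ccc2cc[nH]c2c1)N1CCC[C@@H]1CCN1CCC(c2c[nH]c3ccccc23)CC1` carries 1H-indol-3-yl in place of methyl on a saturated ring carbon. In this assay compound 2 gives 1.29 nM, the only number shown in the set. The step that the limit leaves unreadable from compound 1 to compound 2 therefore has no readable size, the lower value of compound 1 sitting at the limit of < 10000 nM in this assay, at which 1 of the 2 values shown sits. Compound 3 `O=S(=O)(c1ccc2cc[nH]c2c1)N1CCC[C@@H]1CCN1CCC(c2cc3ccccc3[nH]2)CC1` differs from compound 2 by 1H-indol-2-yl in place of 1H-indol-3-yl on a saturated ring carbon; the two have the same atoms, joined differently. No measured step covers this change, as the one step shown runs from methyl to an indole and cannot be read. Compound 3 is therefore expected near compound 2, at an estimated 4 nM with a range from 1 nM to 30 nM. The expected step of a 3.1-fold higher number from compound 2 to compound 3 (0.49 log units; beyond the scatter) is small against the scatter, with room left for some loss.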

Compound 3, inhibition constant: 89.1 nM
Compound 3: the middle estimate sits 22-fold (1.35 log units) below what was measured; the whole stated range lies below it.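

In this assay, exchanging 1H-indol-3-yl for 1H-indol-2-yl on the saturated ring carbon gives a 69-fold higher number from compound 2 to compound 3 (1.84 log units; beyond the scatter), although the two compounds have the same atoms, joined differently. Within the data shown here, this is the only readable step at this position, and it shows that the number depends on how the indole is joined to the ring, not merely on an indole being there. Compound 1 is held only as a limit, so neither step from it can be read: the limit of < 10000 nM in this assay, at which 1 of the 3 values shown sits.

The compounds shown leave open how a phenyl, a 1H-indol-5-yl or a 1H-indol-3-yl carrying a fluorine would read at this ring carbon. Going by these compounds, it also remains open whether the gap between the two indoles would persist with a longer chain between the shared core and the six-membered ring.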